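The source may hold more compounds than are shown below. What is called first, only, known or untested is meant among the compounds shown, and "the series" means these compounds.

Of the compounds shown here, two have been read in a functional assay on MDA-MB-231 cells (Homo sapiens) for cytotoxicity, read by sulforhodamine B assay, with a stated time of 48 h, tested at 0.01 uM; on this read-out lower numbers stand for a stronger effect and higher numbers for a weaker effect at the one concentration tested. Compound 1 `COc1ccc(-c2cc(/C=C/C(=O)c3ccc(N)cc3)[nH]n2)cc1` gives 93% in this assay. Compound 2 `COc1ccc(C(=O)/C=C/c2cc(-c3cc(OC)c(OC)c(OC)c3)n[nH]2)cc1OC`, built on the shared core with a different arrangement of its substituents, gives 104% in this assay. Compound 1 therefore stands lowest of the two numbers; compound 2 is its nearest neighbour, and the gap between them lies beyond the usual scatter. Among the compounds with values here, no pair of measured compounds differs in a single place, so the weight of any one change cannot be read from these numbers.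

Compound 3 `COc1ccc(-c2cc(/C=C/C(=O)c3ccc(N)cc3)[nH]n2)cc1OC` remains to be measured in this assay. It differs from compound 1 by methoxy in place of hydrogen on an aromatic carbon, the entering group sitting on an aromatic carbon of a six-membered aromatic ring of carbon only, ortho to a methoxy group and meta to a large group. Within the data shown here, with no comparable step in hand, the step of a number 2 percentage points higher from compound 1 to compound 3 (within the scatter) is expected to be small, in no direction beyond the scatter. Compound 3 is estimated at 95%, within a range from 84% to 106%.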

Compound 3, a percentage reported as activity, at one concentration (the size of the read-out at that concentration, not a potency): 113%
Compound 3: the middle estimate sits 18 percentage points below what was measured; measured number outside the range, above it.
By their numbers in this assay, from the lowest: compound 1; then compounds 2 and 3 (each within the scatter of the next).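

In this assay, within the data shown here, the replacement of hydrogen by methoxy on an aromatic carbon, ortho to a methoxy group and meta to a large group, gives a number 20 percentage points higher from compound 1 to compound 3 (beyond the scatter) and provides the first reading of a single change. This aromatic carbon is therefore not silent to substitution: adding methoxy here moves the number in the direction of a weaker effect at the one concentration tested, and the step lies beyond the usual scatter. The finding rests on one pair on the core of compound 1 and one concentration, and no measurement at hand accounts for the step.

From the compounds shown here alone, it remains open whether a hydroxy group, a chlorine atom or a longer ethoxy chain on the same aromatic carbon would give a step of similar direction and size, or whether the step is particular to methoxy. Going by these compounds, it is also open whether methoxy in place of hydrogen would give a comparable step if an acetamide stood in place of the amine of compound 1.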